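This account rests on a few compounds, and the source may have more. Where it says the series, first, only, none or still open, it means among the compounds named here.

The three compounds share one core and differ only in the group carried on one aromatic carbon of that core. In an ADME assay on microsomes from liver (Rattus norvegicus) for metabolic stability, with a stated time of 60 min, tested at 1 uM (on this read-out lower numbers stand for a less stable compound and higher numbers for a more stable compound), compound 1 `COc1cc(-c2cnn3cc(OC)c(C(C)C)nc23)ccn1` gives 14%, the second highest of the three numbers. Compound 2 `COc1cc(-c2cnn3cc(OC)c(C)nc23)ccn1` gives 13% in this assay; the step of a number 1 percentage points lower from compound 1 to compound 2 (within the scatter) shows that replacing isopropyl with methyl made no difference that can be trusted. Compound 3 `COc1cc(-c2cnn3cc(OC)c([C@@H]4COC(C)(C)C4)nc23)ccn1` gives 30%, and the steps of a number 16 percentage points higher from compound 1 to compound 3 (beyond the scatter) and a number 17 percentage points higher from compound 2 to compound 3 (beyond the scatter) show that a ring-bearing group of seven heavy atoms in this position raised the remaining fraction by a modest amount.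

Compound 4 `COc1cnc2c(-c3ccnc(OC)c3)cnn2c1` goes the other way: hydrogen in place of isopropyl on an aromatic carbon. The step from isopropyl to methyl already removed most of the group and left this assay unchanged, so removing the last carbon as well is not expected to move the number beyond the scatter; if anything, the direction suggested by the larger group in compound 3 points slightly downward for a smaller one. The expected step is a number 2 percentage points lower from compound 1 to compound 4 (within the scatter), that is essentially none. Compound 4 is therefore estimated at 12% in this assay, within a range from 5% to 25%.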

Compound 4, percent of the compound remaining: 10%
Estimate against measurement, compound 4: 2 percentage points above; measured number inside the range.
By their numbers in this assay, from the lowest: compounds 4, 2 and 1 (each within the scatter of the next); then compound 3.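

With hydrogen on this carbon, the carbon groups can be compared with no group at all: a number 4 percentage points lower from compound 1 to compound 4 (within the scatter) and a number 3 percentage points lower from compound 2 to compound 4 (within the scatter) in this assay show that neither isopropyl nor methyl gives a difference from hydrogen that can be trusted. The other step, a number 20 percentage points lower from compound 3 to compound 4 (beyond the scatter), shows that the group of 7 heavy atoms with its five-membered ring also stands apart from the bare position, so among these four compounds it is the only group at this place that separates from hydrogen. Nothing measured here offers a reason for that difference.

With only one group standing apart, the compounds shown leave open whether the ring, its oxygen, the two extra methyl groups on the ring or simply the number of heavy atoms carries the difference. A cyclopentyl ring, which has a five-membered ring without the oxygen, or a longer chain such as n-pentyl, which has carbon atoms but no ring, would help to separate these possibilities.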